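This account rests on a few compounds, and the source may have more. Where it says the series, first, only, none or still open, it means among the compounds named here.

Working notes on the ester series. For the measured compounds named here, in a functional assay on IMR-32 cells (Homo sapiens) for inhibition, with a stated time of 48 h, tested at 50 uM (on this read-out higher numbers stand for more inhibition of growth at the one concentration tested and lower numbers for less inhibition of growth), compound 2 (`C=C[C@@](C)(/C=C/c1ccc(OC(=O)CCCC)cc1)CCC=C(C)C`) gives 21%, the lower of the two numbers so far, while compound 1 (`C=C[C@@](C)(/C=C/c1ccc(OC(=O)CC)cc1)CCC=C(C)C`) gives 63%. The next compound to be read is compound 3 (`C=C[C@@](C)(/C=C/c1ccc(OC(=O)CCCCC)cc1)CCC=C(C)C`). Its difference from compound 2 is methyl in place of hydrogen on a saturated chain carbon, four bonds along the chain from a carbonyl carbon. In words, this is methyl in place of hydrogen on a saturated chain carbon, four bonds along the chain from a carbonyl carbon.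

Going by the values given here, only one measured step bears on this change: a number 42 percentage points lower from compound 1 to compound 2 (beyond the scatter). That step is large and beyond the scatter, and it comes from ethyl in place of hydrogen on a saturated chain carbon, two bonds along the chain from a carbonyl carbon. It extends the same chain, so it suggests a direction, but a single step establishes no trend. The new change adds less to the chain, and compound 2 already stands low at 21%. A small further fall is therefore expected in this assay, possibly not beyond the scatter. The estimated change is a number 6 percentage points lower from compound 2 to compound 3 (within the scatter). For compound 3 the estimate is 15%, with an expected range of 3% to 34%.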

Compound 3, percent growth inhibition at one concentration: 19%
The estimate for compound 3 lay 4 percentage points below the measured number, and the stated range covers the measured number.
By their numbers in this assay, from the lowest: compounds 3 and 2 (each within the scatter of the next); then compound 1.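

In this assay, methyl in place of hydrogen on a saturated chain carbon, four bonds along the chain from a carbonyl carbon, gives a number 2 percentage points lower from compound 2 to compound 3 (within the scatter) and so, unlike the earlier ethyl change two bonds along the chain, leaves the read-out within the scatter. Over the whole extension the result is a number 44 percentage points lower from compound 1 to compound 3 (beyond the scatter) and, among the listed compounds, the large fall appears at the step from compound 1 to compound 2, while compound 2 and compound 3 cannot be told apart in this read-out. Nothing on hand explains why the further methyl shows no change beyond the scatter when the earlier extension did.

Still open, from the compounds shown here alone, is whether a longer chain on the ester would stay at the level of compound 2 and compound 3 or move away from it, and whether a shorter chain, such as the acetyl ester, would stand above compound 1. Also open, going by these compounds, is whether a branched chain, or an amide in place of the ester, would behave as these three straight-chain esters do at the single concentration tested.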